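A few compounds are considered here, and "the series" means these few. Any claim that something is new, unique, unknown or untested is made for them only; others in the source may bear on it.

Measured so far in an assay on membranes from brain for displacement of a labelled ligand from Sigma non-opioid intracellular receptor 1 (Cavia porcellus), read by scintillation counting, with a stated time of 120 min; on this read-out lower numbers stand for stronger inhibition and higher numbers for weaker inhibition:
compound 1 `Cc1cccc2sc(NC(=O)CCN3CCN(C(C)C)CC3)nc12`: 1300 nM
compound 2 `Cc1cccc2sc(NC(=O)CCN3CCN(CCN(C)C)CC3)nc12`: 1000 nM
compound 3 `Cc1cccc2sc(NC(=O)CCN3CCN(C4CCCCC4)CC3)nc12`: 24 nM

Compound 3 gives the lowest number of the three: a 54-fold lower number from compound 1 to compound 3 (1.73 log units; beyond the scatter) and a 42-fold lower number from compound 2 to compound 3 (1.62 log units; beyond the scatter) are both beyond the scatter, whereas a 1.3-fold lower number from compound 1 to compound 2 (0.11 log units; within the scatter) lies within it. The next compound, compound 4 `Cc1ccccc1N1CCN(CCC(=O)Nc2nc3c(C)cccc3s2)CC1`, carries 2-methylphenyl in place of cyclohexyl on an amine nitrogen in a ring. Within the data shown here, no measured step exchanges one six-membered ring for another on this nitrogen; the two large steps to compound 3 show only that the cyclohexyl ring gives a far lower number than isopropyl or 2-(dimethylamino)ethyl. 2-Methylphenyl keeps a six-membered ring at that position, so the number for compound 4 is expected to stay near that of compound 3. For compound 4 the expected step is a 2.5-fold higher number from compound 3 to compound 4 (0.40 log units; beyond the scatter). Compound 4 is estimated at 60 nM, range 15 nM to 300 nM.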

Compound 4, inhibition constant: 1000 nM
Compound 4: middle estimate off by 17-fold (1.22 log units), on the low side; the whole stated range lies below it.
By their numbers in this assay, from the lowest: compound 3; then compounds 2, 4 and 1 (each within the scatter of the next).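

In this assay, a six-membered ring of carbon only on this nitrogen does not by itself give the low number: 2-methylphenyl in place of cyclohexyl gives a large step (a 42-fold higher number from compound 3 to compound 4 (1.62 log units; beyond the scatter)). 2-Methylphenyl instead falls level with the two open-chain groups (no change at the digits printed from compound 2 to compound 4 (within the scatter); a 1.3-fold lower number from compound 1 to compound 4 (0.11 log units; within the scatter)), so among these four compounds only cyclohexyl stands apart. Nothing available explains this difference.

On these data alone, whether the step follows from the aromatic ring or from its methyl group stays open. Phenyl and cyclopentyl on this nitrogen would separate those two readings.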